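A few compounds are considered here, and "the series" means these few. Any claim that something is new, unique, unknown or untested is made for them only; others in the source may bear on it.

Measured so far in a functional assay on HCC827 cells (Homo sapiens) for inhibition, read by MTT assay, with a stated time of 48 h, tested at 10 uM; a lower number here means less inhibition, a higher number more inhibition at the concentration tested (going by the name of the read-out):

Compound 1, `COc1ccc(F)cc1Nc1cc(NC(=O)Nc2c(Cl)cccc2Cl)ncn1`: 78%
Compound 2, `COc1ccc(C(F)(F)F)cc1Nc1cc(NC(=O)Nc2c(Cl)cccc2Cl)ncn1`: 68.7%

Among the compounds with values here, compound 2 and compound 1 lie within the scatter of each other in this assay; the only step in the set, a number 9.3 percentage points lower from compound 1 to compound 2 (within the scatter), does not separate them, so no order between the two can be read from these numbers.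

Compound 3, `COc1ccc(OC)c(Nc2cc(NC(=O)Nc3c(Cl)cccc3Cl)ncn2)c1`, is not yet measured. Its change from compound 2 is methoxy in place of trifluoromethyl on an aromatic carbon. Within the data shown here, only one measured step bears on this: the same position of the ring carried fluoro in compound 1 and trifluoromethyl in compound 2, and that exchange gave a number 9.3 percentage points lower from compound 1 to compound 2 (within the scatter), within the scatter. Among the measured compounds shown here, a second exchange at that same position, trifluoromethyl for methoxy, has no direct precedent here, and the one precedent at the site shows no movement beyond the scatter. The expectation is therefore a step of a number 3.3 percentage points higher from compound 2 to compound 3 (within the scatter), that is, no change beyond the scatter in either direction.

Compound 3 is estimated at 72% in this assay, with a range from 55% to 85%.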

Compound 3, a percentage reported as inhibition, at one concentration (the size of the read-out at that concentration, not a potency): 94.1%
The estimate for compound 3 lay 22.1 percentage points below the measured number, outside the stated range (above it).
By their numbers in this assay, from the lowest: compounds 2 and 1 (each within the scatter of the next); then compound 3.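

In this assay, the position para to a methoxy group now proves able to separate compounds: methoxy in place of trifluoromethyl gives the larger step (a number 25.4 percentage points higher from compound 2 to compound 3 (beyond the scatter)), and methoxy in place of fluoro also clears the scatter (a number 16.1 percentage points higher from compound 1 to compound 3 (beyond the scatter)). Within the data shown here, the earlier exchange of fluoro for trifluoromethyl at this position gave no separation, so the site looked flat until methoxy entered, and compound 3 (94.1%) is now the only compound of the three with steps to both others printed as beyond the scatter. No data on hand bear on why methoxy stands apart from the two other groups at this position.

Among these compounds, with only three groups at this position, it remains open whether the gain is particular to methoxy or extends to an ethoxy group, a hydroxyl or an amine there. As far as these compounds go, it also remains open how compound 3 would compare on a full concentration series, as each read-out here reflects a single tested concentration and is not a potency.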